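Trifluoromethoxy in place of fluoro: compound 1 to compound 3

The source may hold more compounds than are shown below. What is called first, only, known or untested is meant among the compounds shown, and "the series" means these compounds.

Compound 1 (`OC[C@H]1O[C@@H](n2cnc3c(NCc4cccc(F)c4)ncnc32)[C@H](O)[C@@H]1O`) opens this step. In a functional assay on G-361 cells (Homo sapiens) for antiproliferative activity, with a stated time of 72 h (a higher number here means a weaker inhibitor, a lower number a stronger inhibitor), compound 1 gives > 166000 nM, which is a limit and not a number. Going by the values given here, compound 2 (`OC[C@H]1O[C@@H](n2cnc3c(NCc4ccccc4OC(F)F)ncnc32)[C@H](O)[C@@H]1O`) is the only measured neighbour. In this assay compound 2 gives > 166000 nM, which is also a limit. The measured set therefore comes down to the limit of > 166000 nM in this assay, at which 2 of the 2 values shown sit, and compound 1 has no numerical position within it.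

Among the compounds with values here, the one measured step is a step that the two limits leave unreadable from compound 1 to compound 2. It offers no size to carry over, only the observation that compound 2, with its changed substituent, gave no number either.

Compound 3 (`OC[C@H]1O[C@@H](n2cnc3c(NCc4cccc(OC(F)(F)F)c4)ncnc32)[C@H](O)[C@@H]1O`) retains the core of compound 1 and differs at one place: trifluoromethoxy in place of fluoro on an aromatic carbon. This is trifluoromethoxy in place of fluoro on an aromatic carbon, meta to a large group.

With no readable step to draw on, no shift beyond the scatter is expected in this assay, and neither direction is favoured. The estimated step is a number no higher from compound 1 to compound 3 (the limit leaves the size open). A report of only a limit is the most likely outcome. The expected value for compound 3 is 166000 nM, with an estimated range from 60000 nM to 300000 nM.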

Compound 3, half-maximal inhibitory concentration: > 166000 nM
Compound 3 gave a limit, no number; the forecaster's own chance of this, stated with the estimate: 80%; the middle value sits exactly at the limit.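

No step can be read between compound 1 and compound 3: each gave only a limit in this assay, not a number. The compounds shown leave open whether any change to this substituent on the shared core yields a readable value at all, and the series still rests on a single limit: the limit of > 166000 nM in this assay, at which 3 of the 3 values shown sit.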